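The source may hold more compounds than are shown below. What is called first, only, known or untested is meant among the compounds shown, and "the series" means these compounds.

Measured so far:
- compound 1 `COc1ccc(C(=O)/C=C/c2cc3ccccc3[nH]c2=O)cc1`; in an ADME assay on NCI-H460 cells (Homo sapiens) for cytotoxicity, read by sulforhodamine B assay, with a stated time of 24 h (on this read-out lower numbers stand for higher toxicity in this test and higher numbers for lower toxicity in this test), compound 1 gives 66800 nM
- compound 2 `O=C(/C=C/c1cc2ccccc2[nH]c1=O)c1ccc(O)cc1`; in this assay compound 2 gives only a limit, > 100000 nM

Compound 2 stands at the ceiling of this assay, with no number of its own: the limit of > 100000 nM in this assay, at which 1 of the 2 values shown sits. Among the measured compounds shown here, compound 1 gives a number a little under that ceiling, and the one measured step, an at least 1.4-fold higher number from compound 1 to compound 2 (0.17 log units; that floor lies within the scatter), is small and concerns a methyl on an oxygen, not the group exchanged here.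

Compound 3 `O=C(/C=C/c1cc2ccccc2[nH]c1=O)c1ccc(Cl)cc1` differs from compound 2 by chloro in place of hydroxy on an aromatic carbon. For the measured compounds named here, no measured step bears on swapping hydroxy for chloro, so the expectation rests only on where compound 2 and compound 1 sit, both near the top of the range of this assay. A number beyond the scatter in either direction is not expected with confidence; a value near the limit, or again only the limit, is the likeliest outcome.

For compound 3 the estimate in this assay is 60000 nM, with a range from 20000 nM to 150000 nM, which means an expected step of an at least 1.6-fold lower number from compound 2 to compound 3 (0.22 log units; that floor lies within the scatter).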

Compound 3, concentration lethal to 50% of the cells: > 100000 nM
Compound 3 was reported as a limit; the forecaster's own chance of this, stated with the estimate: 35%; at least 1.6-fold (0.22 log units) between middle value and limit.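

In this assay, chloro in place of hydroxy on an aromatic carbon, para to a large group, brings no number under the ceiling, and the hydroxy group proves not to be needed for a result at the limit: the limit of > 100000 nM in this assay, at which 2 of the 3 values shown sit.
With limits on both sides, the step between compound 2 and compound 3 cannot be read. Chloro in place of methoxy gives an at least 1.4-fold higher number from compound 1 to compound 3 (0.17 log units; that floor lies within the scatter), which does not separate the two, and the methoxy compound remains the only one here with a number of its own.

As far as these compounds go, what an amine or a carboxylic acid at this place would give in this assay stays open, as does whether any group here can bring the value clearly below the limit. Changes to the shared core, or to the chain that links it to the aromatic ring, also remain open.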